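Extending the Ether Side Chain: An Expected Cytotoxicity Value

The source may hold more compounds than are shown below. What is called first, only, known or untested is meant among the compounds shown, and "the series" means these compounds.

Compound 1 `CCOC(=O)c1c(C)coc1-c1ccc2c(CC)cccc2c1OC` gives 1.8 ug/mL in a functional assay on KBVIN cells (Homo sapiens) for cytotoxicity, read by MTT assay, with a stated time of 72 h; on this read-out lower numbers stand for an effect already at smaller amounts and higher numbers for an effect only at larger amounts of compound.
Compound 2 `CCc1cccc2c(OC)c(-c3occ(C)c3C(=S)OC)ccc12` gives 5.1 ug/mL in this assay.
Compound 3 `CCc1cccc2c(OC)c(-c3occ(C)c3COC)ccc12` gives 8.8 ug/mL in this assay.

Compound 3 carries the highest number of the three. One gap is a 1.7-fold higher number from compound 2 to compound 3 (0.24 log units; within the scatter), so these two cannot be placed in any order. The other gap is a 4.9-fold higher number from compound 1 to compound 3 (0.69 log units; beyond the scatter), a real difference.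

Compound 4 `CCOCc1c(C)coc1-c1ccc2c(CC)cccc2c1OC` differs from compound 3 by methyl in place of hydrogen on a saturated chain carbon bound to an oxygen on a saturated carbon. The methoxymethyl of compound 3 thus becomes an ethoxymethyl.

Among the compounds with values here, none of the measured steps is of this kind. Each of them, a 2.8-fold higher number from compound 1 to compound 2 (0.45 log units; beyond the scatter), a 4.9-fold higher number from compound 1 to compound 3 (0.69 log units; beyond the scatter) and a 1.7-fold higher number from compound 2 to compound 3 (0.24 log units; within the scatter), replaces the whole group at this aromatic carbon rather than lengthening a chain within it. The closest comparison, the exchange between compound 2 and compound 3, stays within the scatter even though the groups differ more than a single methyl. A change as small as one added methyl on a chain that already sits at this position is therefore not expected to move the number beyond the scatter in this assay.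

The step from compound 3 to compound 4 is expected to be a 1.0-fold lower number from compound 3 to compound 4 (0.02 log units; within the scatter). Compound 4 is estimated at 8.5 ug/mL, with a likely range from 4 ug/mL to 17 ug/mL.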

Compound 4, concentration for half-maximal effect: > 10 ug/mL
Compound 4 was reported as a limit; the forecaster's own chance of this, stated with the estimate: 5%; middle value at least 1.1-fold (0.07 log units) away from the limit.
By their numbers in this assay, from the lowest: compound 1; then compounds 2 and 3 (each within the scatter of the next). At a limit, above all of these: compound 4.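

In this assay compound 4 is recorded only as a limit, not as a number: the limit of > 10 ug/mL in this assay, at which 1 of the 4 values shown sits. This is the first change shown inside the chain rather than an exchange of the whole group, and going from methoxymethyl to ethoxymethyl gives an at least 1.1-fold higher number from compound 3 to compound 4 (0.05 log units; that floor lies within the scatter), so the methyl step may be small or large and its true size remains unknown. Against the other two compounds, the data show an at least 1.9-fold higher number from compound 2 to compound 4 (0.29 log units; that floor lies within the scatter), which also gives no firm order, and an at least 5.5-fold higher number from compound 1 to compound 4 (0.74 log units; beyond the scatter), which is a real gap: with the ethoxy end present in both groups, ethoxycarbonyl and ethoxymethyl are clearly separated in this assay.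

The compounds shown leave open where the number of compound 4 actually lies, and so how much one added methyl changes the result at this position. They also leave open how a longer chain such as propoxymethyl, or an amine or a carboxylic acid on this aromatic carbon, would compare with the ethoxycarbonyl of compound 1.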